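The compounds below may be only part of what the source reports. "The series", "measured", "known", "first", "only" and "open" are said of these compounds alone.

Among the compounds with values here, compound 2 `Cc1cc(Cl)ccc1Nc1nc(C(F)(F)F)ccc1C(=O)N/N=C/c1ccc(N(C)C)cc1` stands at the highest of the two numbers measured so far in a functional assay on NCI60 cells (Homo sapiens) for cytotoxicity, read by sulforhodamine B assay, with a stated time of 48 h (a higher number here means a weaker inhibitor of growth, a lower number a stronger inhibitor of growth), giving 66100 nM. Its nearest neighbour, compound 1 `Cc1cc(Cl)ccc1Nc1nc(C(F)(F)F)ccc1C(=O)N/N=C/c1ccc([N+](=O)[O-])cc1`, gives 4680 nM in this assay. Within the data shown here, the only measured step, a 14-fold higher number from compound 1 to compound 2 (1.15 log units; beyond the scatter), touches the same position that compound 3 `Cc1cc(Cl)ccc1Nc1nc(C(F)(F)F)ccc1C(=O)N/N=C/c1ccc(F)cc1` alters: fluoro in place of dimethylamino on an aromatic carbon. That single step was large, so a sizeable move is expected here as well, in the direction of a lower number, although a swap that brings in fluoro has not itself been measured. Compound 3 is therefore estimated at 12000 nM, with a range from 3000 nM to 45000 nM. The expected step is a 5.5-fold lower number from compound 2 to compound 3 (0.74 log units; beyond the scatter).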

Compound 3, concentration for total growth inhibition: 7080 nM
The estimate for compound 3 lay 1.7-fold (0.23 log units) above the measured number, and the stated range covers the measured number.
By their numbers in this assay, from the lowest: compounds 1 and 3 (each within the scatter of the next); then compound 2.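

Placing fluoro where dimethylamino stood gives a 9.3-fold lower number from compound 2 to compound 3 (0.97 log units; beyond the scatter) in this assay, so the weak reading of compound 2 is not shared by every replacement at this position. Fluoro and nitro cannot be told apart here, with a 1.5-fold higher number from compound 1 to compound 3 (0.18 log units; within the scatter), so among these three groups only dimethylamino stands apart. Nothing available explains this difference. On these data alone, it remains open whether a plain amine or a methoxy group on this aromatic carbon would read like dimethylamino or like fluoro and nitro.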